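A few compounds are considered here, and "the series" means these few. Any claim that something is new, unique, unknown or untested is made for them only; others in the source may bear on it.

The series shares one core, carried by compound 1 `CN(C)C(=O)c1cc2cnc(Nc3ccc(S(=O)(=O)NCCCCN=C=S)cc3)nc2n1C1CCCC1`, compound 2 `CN(C)C(=O)c1cc2cnc(Nc3ccc(S(=O)(=O)NCCCCCCN=C=S)cc3)nc2n1C1CCCC1` and compound 3 `CN(C)C(=O)c1cc2cnc(Nc3ccc(C(=O)NCCCCCCN=C=S)cc3F)nc2n1C1CCCC1`, each ending in an isothiocyanate on a flexible chain. In a functional assay on NCI-H1299 cells (Homo sapiens) for inhibition, read by CCK-8 assay, with a stated time of 72 h, tested at 1 uM (a higher number here means a stronger effect of the compound at the concentration tested, a lower number a weaker effect), compound 1 gives 29.9%, the second highest of the three numbers; compound 3 gives 29.1%, within the scatter of compound 1, while compound 2 gives 42.4%. Among the compounds with values here, the one clean step among them, a number 12.5 percentage points higher from compound 1 to compound 2 (beyond the scatter), shows that a longer chain between the sulfonamide nitrogen and the isothiocyanate went with a modestly higher inhibition.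

Compound 4 `CN(C)C(=O)c1cc2cnc(Nc3ccc(NC(=O)CCCN=C=S)cc3)nc2n1C1CCCC1` is not yet measured. It differs from compound 1 by a group of 9 heavy atoms (5 carbon, 2 nitrogen, 1 oxygen, 1 sulfur; no ring) in place of a group of 11 heavy atoms (5 carbon, 2 nitrogen, 2 oxygen, 2 sulfur; no ring), on an aromatic carbon. Here the sulfonamide is gone and an amide linker carries the isothiocyanate on a shorter chain. Within the data shown here, no measured step covers the change of linker, so the only guide is the chain-length step from compound 1 to compound 2, which points the other way when the chain is shortened, and the value of compound 3, where an amide linker sits near compound 1. Compound 4 is therefore expected to come out somewhat lower than compound 1, by a number 5.9 percentage points lower from compound 1 to compound 4 (within the scatter), though this may stay within the scatter. The estimate for compound 4 is 24%, with a range from 10% to 38%.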

Compound 4, a percentage reported as inhibition, at one concentration (the size of the read-out at that concentration, not a potency): 39.7%
For compound 4 the middle estimate is 15.7 percentage points below the measured one; the measured number lies above the stated range.
By their numbers in this assay, from the lowest: compounds 3, 1, 4 and 2 (each within the scatter of the next, the first and the last beyond it).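

At the aromatic carbon para to a large group, replacing the sulfonamide-linked chain of compound 1 with the amide-linked chain of compound 4 gives a number 9.8 percentage points higher from compound 1 to compound 4 (within the scatter) in this assay, so this change can be called neither a gain nor a loss. The sulfonamide is therefore not needed at this position for inhibition of this size in the pair, and the shorter chain of compound 4 does not bring a drop beyond the scatter, which the chain-length step among the sulfonamides alone could not have shown. Linker and chain change together in this one step, so their separate contributions cannot be told apart, and nothing available explains why the inhibition holds at this position.

The compounds shown leave open how a sulfonamide carrying the same shorter chain, or the same amide carrying a longer chain, would behave, which would separate the two changes. They also leave open whether the isothiocyanate itself is needed, since every compound here ends in that group and none ends in an amine or a carboxylic acid on the same chain.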